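This account rests on a few compounds, and the source may have more. Where it says the series, first, only, none or still open, it means among the compounds named here.

In an in vitro assay on cells for displacement of a labelled ligand from 5-hydroxytryptamine receptor 1B (Homo sapiens) (on this read-out lower numbers stand for stronger inhibition and higher numbers for weaker inhibition), compound 2, with the structure `N#Cc1ccc2c(N3CCN(CC[C@@H]4OCCc5cc(C(N)=O)ccc54)CC3)cccc2c1`, gives 15 nM. Compound 3, with the structure `C[C@H]1CN(c2cccc3cc(F)ccc23)CCN1CC[C@@H]1OCc2cc(C(N)=O)ccc21`, gives 114 nM in this assay, the highest of the two plain numbers, sitting a step above compound 2 that lies beyond the scatter of the method. Compound 1, with the structure `NC(=O)c1ccc2c(c1)CCO[C@H]2CCN1CCN(c2ccc3cc(F)ccc3c2)CC1`, gives > 1000 nM in this assay; that figure is a limit of the method rather than a number, a limit at which one of the three values sits (the limit of > 1000 nM in this assay, at which 1 of the 3 values shown sits).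

The step under view goes from compound 3 to compound 4, with the structure `C[C@H]1CN(c2cccc3cc(F)ccc23)CCN1CC[C@H]1OCc2cc(C(N)=O)ccc21`. The change is purely one of configuration: the two compounds have the same atoms and bonds and differ only in configuration as drawn: 1 of 2 stereo elements differ; a stereocentre at a saturated ring carbon is drawn S in compound 3 and R in compound 4. Inverting a single stereocentre can move binding in either direction, and nothing among the measured pairs here isolates that change on its own. Still, compound 1 is drawn with the opposite configuration at that carbon to compound 2, and in this assay compound 1 sits at a limit of > 1000 nM. On that ground compound 4 is expected to bind more weakly than compound 3, by a step of a 3.5-fold higher number from compound 3 to compound 4 (0.55 log units; beyond the scatter). The estimate for compound 4 in this assay is 400 nM, within a range from 80 nM to 2000 nM.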

Compound 4, inhibition constant: > 1000 nM
Compound 4 gave a limit, no number; the forecaster's own chance of this, stated with the estimate: 25%; middle value at least 2.5-fold (0.39 log units) away from the limit.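

This is the first pair shown that isolates a single change, and in this assay it gives an at least 8.7-fold higher number from compound 3 to compound 4 (0.94 log units; beyond the scatter). The loss of binding can be traced to the configuration at this saturated ring carbon, because nothing else in the structures differs: the fact that compounds 3 and 4 differ only in the configuration as drawn. In this assay, from the compounds shown here alone, compound 4 gives > 1000 nM, which is a limit and not a number, so the true size of the step stays unknown: the limit of > 1000 nM in this assay, at which 2 of the 4 values shown sit.

The compounds shown leave open how much weaker the R form really is, and whether inverting this carbon has a similar effect when the rest of the molecule differs. They also do not tell how binding would respond to a hydroxyl group at this same carbon.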